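The source may report more compounds than this note shows. Statements on the series, on what has been measured and on what is new or still open speak of the compounds shown alone.

Measured so far:
- compound 1, `CC1CCC(Nc2nc(C(F)(F)F)ccc2CNC(=O)C(C)c2ccc(NS(C)(=O)=O)c(F)c2)CC1`: 27.2 nM
- compound 2, `CC(C(=O)NCc1ccc(C(F)(F)F)nc1Nc1ccc(F)cc1)c1ccc(NS(C)(=O)=O)c(F)c1`: 39.2 nM
- compound 3, `CCCN(CCC)c1nc(C(F)(F)F)ccc1CNC(=O)C(C)c1ccc(NS(C)(=O)=O)c(F)c1`: 0.2 nM

In a functional assay on CHO-K1 cells for antagonist activity at transient receptor potential cation channel subfamily V member 1 (Homo sapiens), read by FLIPR (on this read-out lower numbers stand for stronger inhibition and higher numbers for weaker inhibition), compound 2 gives 39.2 nM, the highest of the three numbers; compound 1 sits close to it, while compound 3 lies far lower. The two steps from the amino-linked compounds to compound 3 are large: a 140-fold lower number from compound 1 to compound 3 (2.13 log units; beyond the scatter) and a 200-fold lower number from compound 2 to compound 3 (2.29 log units; beyond the scatter). In both, a group carrying one hydrogen-bond donor on the ring carbon gives way to dipropylamino, which carries none, and the number falls steeply.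

Compound 4, `CC(C(=O)NCc1ccc(C(F)(F)F)nc1N1CCCC1)c1ccc(NS(C)(=O)=O)c(F)c1`, has not yet been measured. It differs from compound 2 in one place: pyrrolidin-1-yl in place of (4-fluorophenyl)amino on an aromatic carbon. Like dipropylamino, pyrrolidin-1-yl brings 0 hydrogen-bond donors to that carbon, so the step most closely related is a 200-fold lower number from compound 2 to compound 3 (2.29 log units; beyond the scatter). Pyrrolidin-1-yl is not dipropylamino, and no measured pair tells how a five-membered ring compares with two propyl chains, so a somewhat smaller drop is the cautious expectation.

For compound 4 the expected step is a 26-fold lower number from compound 2 to compound 4 (1.42 log units; beyond the scatter), well beyond the scatter and downward. Compound 4 is therefore estimated at 1.5 nM in this assay, with a plausible range from 0.3 nM to 8 nM.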

Compound 4, inhibition constant: 0.6 nM
Compound 4: the middle estimate sits 2.5-fold (0.40 log units) above what was measured; the measured number falls inside the stated range.
By their numbers in this assay, from the lowest: compound 3; then compound 4; then compounds 1 and 2 (each within the scatter of the next).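

In this assay, the steep fall seen with dipropylamino also appears with a different group on this aromatic carbon: pyrrolidin-1-yl, a five-membered non-aromatic ring with 0 hydrogen-bond donors, gives a 65-fold lower number from compound 2 to compound 4 (1.82 log units; beyond the scatter) and a 45-fold lower number from compound 1 to compound 4 (1.66 log units; beyond the scatter). Across the four compounds, the two groups with 1 hydrogen-bond donor give the high numbers and the two with 0 give the low numbers, with no compound going against this, yet the two groups without a donor are not equal (a 3.0-fold higher number from compound 3 to compound 4 (0.48 log units; beyond the scatter)). Nothing measured here explains either the large falls or the modest gap between the two groups without a donor.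

The groups compared also differ in size and shape, so the donor count may not be what matters; a methyl on the linking nitrogen of (4-fluorophenyl)amino would change that count while leaving the aromatic ring in place. As far as these compounds go, how far the ring form can vary also stays open, for instance with piperidin-1-yl, which has one more carbon, or morpholin-4-yl, which has an oxygen in the ring.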